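Aryl variation in a cytotoxicity series

The source may report more compounds than this note shows. Statements on the series, on what has been measured and on what is new or still open speak of the compounds shown alone.

Compound 1 `CCOC(=O)c1c(-c2cc(F)cc(OC)c2)[nH]c2cc(OC)ccc2c1=O` gives > 22000 nM in an ADME assay on HEK293 cells (Homo sapiens) for cytotoxicity, read by luminescence, with a stated time of 72 h (on this read-out higher numbers stand for an effect only at larger amounts of compound and lower numbers for an effect already at smaller amounts), which is a limit of the assay and not a number. Compound 2 `CCOC(=O)c1c(-c2cccc(S(C)(=O)=O)c2)[nH]c2cc(OC)ccc2c1=O` also sits at a limit, giving > 22000 nM in this assay. Among the measured compounds shown here, the only evidence is the limit of > 22000 nM in this assay, at which 2 of the 2 values shown sit, so compound 1 stands at the limit with no measured step to any other compound. Compound 3 `CCOC(=O)c1c(-c2cccc(CO)c2)[nH]c2cc(OC)ccc2c1=O` is not yet measured; it differs from compound 1 by 3-(hydroxymethyl)phenyl in place of 3-fluoro-5-methoxyphenyl on an aromatic carbon. With no measured step shown, the step of a number no higher from compound 1 to compound 3 (the limit leaves the size open) is expected to be none beyond the scatter. Compound 3 is therefore estimated at 22000 nM, within 10000 nM to 50000 nM.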

Compound 3, half-maximal effective concentration: > 22000 nM
Compound 3 ended at the assay's limit; the forecaster's own chance of this, stated with the estimate: 85%; the middle value sits exactly at the limit.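

No step can be read among compound 1, compound 2 and compound 3, as each value is a limit of the assay and not a number: the limit of > 22000 nM in this assay, at which 3 of the 3 values shown sit.

The compounds shown leave open whether any aryl group on the shared core gives a readable value in this assay.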